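This account rests on a few compounds, and the source may have more. Where it says the series, first, only, none or still open, it means among the compounds named here.

Working notes on the series. Compound 2 `COc1ccc(C2CC(c3ccc(O)cc3)=NN2C(=O)c2cccnc2)cc1` carries a 4-methoxyphenyl on a saturated ring carbon; in an ADME assay on HepG2 cells (Homo sapiens) for cytotoxicity, read by MTT assay, with a stated time of 7 days (on this read-out higher numbers stand for weaker inhibition and lower numbers for stronger inhibition), compound 2 gives 42400 nM. Compound 1 `CCc1ccccc1C1CC(c2ccc(O)cc2)=NN1C(=O)c1cccnc1` carries a 2-ethylphenyl at that saturated ring carbon; in this assay compound 1 gives 35400 nM. Compound 2 stands at the top of the two numbers shown, with compound 1 nearest, but the only step shown, a 1.2-fold higher number from compound 1 to compound 2 (0.08 log units; within the scatter), lies within the scatter, so nothing separates the two compounds.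

Compound 3 `O=C(c1cccnc1)N1N=C(c2ccc(O)cc2)CC1c1ccc([N+](=O)[O-])cc1` is the next member: nitro in place of methoxy on an aromatic carbon. Within the data shown here, the one measured step that bears on this place is the one from compound 1 to compound 2, which exchanged the whole aryl group and moved the number by a 1.2-fold higher number from compound 1 to compound 2 (0.08 log units; within the scatter) only. With a single step to go on, and that one flat, there is no basis for expecting a move beyond the scatter in this assay when nitro replaces methoxy.

The number for compound 3 in this assay is estimated at 40000 nM, within a range of 15000 nM to 100000 nM. That estimate means an expected step of a 1.1-fold lower number from compound 2 to compound 3 (0.03 log units; within the scatter), kept within the scatter.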

Compound 3, half-maximal inhibitory concentration: 18600 nM
Estimate against measurement, compound 3: 2.2-fold (0.33 log units) above; the range from low to high includes it.
By their numbers in this assay, from the lowest: compounds 3, 1 and 2 (each within the scatter of the next, the first and the last beyond it).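

Among these compounds, on the aryl group at the saturated ring carbon, nitro in place of methoxy, on an aromatic carbon para to a large group, gives the first step beyond the scatter in this assay (a 2.3-fold lower number from compound 2 to compound 3 (0.36 log units; beyond the scatter)), and that step is modest in size. Among the compounds shown here, the aryl group is therefore not wholly flat in this assay, as the single earlier step might have suggested, yet the reach remains small: the exchange of the whole aryl group, 4-nitrophenyl in place of 2-ethylphenyl, gives only (a 1.9-fold lower number from compound 1 to compound 3 (0.28 log units; within the scatter)), which lies within the scatter, so compound 3 and compound 1 cannot be told apart, just as compound 1 and compound 2 could not. No measurement on hand offers any explanation for the step from methoxy to nitro.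

Open, from the compounds shown here alone, is whether this step is particular to nitro or would also appear with an amine, a carboxylic acid or a nitrile at the same place. Also open is whether nitro would give a similar step with the rest of the shared core changed, since only one such pair is shown.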